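The compounds below may be only part of what the source reports. "The series", "measured", "known", "first", "only" and "open" are said of these compounds alone.

Within the data shown here, in a functional assay on HCT-116 cells (Homo sapiens) for antiproliferative activity, with a stated time of 48 h (a lower number here means a stronger inhibitor of growth, a higher number a weaker inhibitor of growth), compound 2 `Cc1cc(O)c(C2=NN(c3ccc(S(N)(=O)=O)cc3)C(/C=C/c3ccccc3)C2)cc1Cl` gives 2400 nM; the only other measured compound, compound 1 `Cc1cc(O)c(C2=NN(c3ccc(S(N)(=O)=O)cc3)C(c3ccccc3O)C2)cc1Cl`, gives 1660 nM, and the step of a 1.4-fold higher number from compound 1 to compound 2 (0.16 log units; within the scatter) lies within the scatter, so the two stand together. Compound 3 `COc1ccc(C2CC(c3cc(Cl)c(C)cc3O)=NN2c2ccc(S(N)(=O)=O)cc2)c(OC)c1OC` differs from compound 2 by 2,3,4-trimethoxyphenyl in place of 2-phenylethenyl on a saturated ring carbon. Among the measured compounds shown here, the single measured step at this saturated ring carbon, from compound 1 to compound 2, was small, so no firm direction can be read for a new group there; a step near the scatter is expected, a 1.2-fold lower number from compound 2 to compound 3 (0.08 log units; within the scatter). Compound 3 is therefore estimated at 2000 nM, with a range from 700 nM to 6000 nM.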

Compound 3, concentration for 50% growth inhibition: 1630 nM
For compound 3 the middle estimate is 1.2-fold (0.09 log units) above the measured one; measured number inside the range.
By their numbers in this assay, from the lowest: compounds 3, 1 and 2 (each within the scatter of the next).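

With 2,3,4-trimethoxyphenyl, this saturated ring carbon now carries a group of 12 heavy atoms with 3 hydrogen-bond acceptors, yet in this assay the numbers stay together (a 1.5-fold lower number from compound 2 to compound 3 (0.17 log units; within the scatter); a 1.0-fold lower number from compound 1 to compound 3 (0.01 log units; within the scatter)). Across these three compounds, then, swapping one aromatic-ring-bearing group for another at this position gives no step beyond the scatter. No measurement shown offers a reason for this. On these data alone, all three groups carry a six-membered aromatic ring of carbon only, so it remains open how an amine, a carboxylic acid or a plain alkyl chain would behave here.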